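The source may hold more compounds than are shown below. What is called first, only, known or untested is meant among the compounds shown, and "the series" means these compounds.

Among the compounds with values here, in a physicochemical assay for lipophilicity, read by HPLC (on this read-out higher numbers stand for higher lipophilicity and lower numbers for lower lipophilicity), compound 2 `Cc1ccsc1C(=CCCN(C)C(CCO)C(=O)NCc1ccc(Cl)cc1)c1sccc1C` reads 6.38, the only number it has, and this falls inside the spread of compound 1 `Cc1ccsc1C(=CCCN(C)C(CC(C)O)C(=O)NCc1ccc(Cl)cc1)c1sccc1C` at 5.99; 6.77 (2 entries). Compound 3 `Cc1ccsc1C(=CCCN(C)C(CO)C(=O)NCc1ccc(Cl)cc1)c1sccc1C` carries hydroxy in place of hydroxymethyl on a saturated chain carbon, two bonds along the chain from an amine nitrogen and a carbonyl carbon. Within the data shown here, no measured step speaks to this change, so only a modest fall in this assay is expected, estimated as a number 0.38 log units lower from compound 2 to compound 3 (beyond the scatter). A wide range is kept because compound 1 alone shows 5.99; 6.77 (2 entries). Compound 3 is estimated at 6, with an expected range of 5.4 to 6.6.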

Compound 3, partition coefficient: 6.47
Estimate against measurement, compound 3: 0.47 log units below, within the range that was stated.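

Going from 2-hydroxyethyl to hydroxymethyl on this saturated chain carbon gives, in this assay, a number 0.09 log units higher from compound 2 to compound 3 (within the scatter). Within the data shown here, this is the first step that can be read at this place, and across this one pair the change does not separate the two compounds. Single readings here carry limited weight, because entries for one compound can lie far apart: the several entries of compound 1 in this assay, 5.99; 6.77 (2 entries)

Every compound shown ends this chain in hydroxy, so the result says nothing about an amine or a carboxylic acid at this place. Going by these compounds, whether a longer chain or a plain methyl group would read differently also stays open.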